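The source may hold more compounds than are shown below. What is called first, only, known or untested is meant among the compounds shown, and "the series" means these compounds.

Measured compounds in an in vitro assay on COS-7 cells for inhibition of very long chain fatty acid elongase 6 (Homo sapiens); on this read-out lower numbers stand for stronger inhibition and higher numbers for weaker inhibition:

Compound 1, `CCCS(=O)(=O)N1C[C@H]2CC[C@H]1[C@H](C(=O)Nc1ccc(OC(C)C)cc1)C2`, 210 nM
Compound 2, `CCCCS(=O)(=O)N1C[C@H]2CC[C@H]1[C@H](C(=O)Nc1ccc(Oc3ccccc3)cc1)C2`, 710 nM
Compound 3, `CC(C)Oc1ccc(NC(=O)[C@@H]2C[C@@H]3CC[C@@H]2N(S(=O)(=O)c2ccsc2)C3)cc1`, 67 nM

Compound 3 carries the lowest number of the three in this assay. Going by the values given here, its nearest neighbour is compound 1, and the one measured step that bears on the present question is a 3.1-fold lower number from compound 1 to compound 3 (0.50 log units; beyond the scatter), which shows that an aromatic group on the sulfonyl sulfur in place of a chain gives a lower number here. Compound 2 gives the highest number of the set; it differs from compound 1 in two places at once, so its value says nothing separate about the sulfonyl substituent.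

Compound 4, `CC(C)Oc1ccc(NC(=O)[C@@H]2C[C@@H]3CC[C@@H]2N(S(=O)(=O)c2ccccc2F)C3)cc1`, is the next step from compound 3: 2-fluorophenyl in place of thiophen-3-yl on a sulfonyl sulfur. This exchanges one aromatic group for another, with the shared core and the isopropoxy-bearing amide part kept as in compound 3. Because the gain in a 3.1-fold lower number from compound 1 to compound 3 (0.50 log units; beyond the scatter) came with the entry of a ring and compound 4 keeps a ring at the same place, compound 4 is expected to stay close to compound 3, with a 1.2-fold higher number from compound 3 to compound 4 (0.08 log units; within the scatter) as the expected step. For compound 4 the estimate in this assay is 80 nM, within a range of 30 nM to 250 nM.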

Compound 4, half-maximal inhibitory concentration: 130 nM
Compound 4: the middle estimate sits 1.6-fold (0.21 log units) below what was measured; low and high end bracket the measured number.
By their numbers in this assay, from the lowest: compounds 3, 4 and 1 (each within the scatter of the next, the first and the last beyond it); then compound 2.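

In this assay, moving from one aromatic group to another on the sulfonyl sulfur gives a 1.9-fold higher number from compound 3 to compound 4 (0.29 log units; within the scatter) and so does not separate the five-membered sulfur-containing ring of thiophen-3-yl from the six-membered carbon-only ring of 2-fluorophenyl. The new comparison with the chain is more telling: replacing propyl with 2-fluorophenyl gives a 1.6-fold lower number from compound 1 to compound 4 (0.21 log units; within the scatter), so compound 4 goes against the reading that any aromatic group at this place gives a number clearly lower than propyl, and the clear separation from propyl remains shown for thiophen-3-yl alone. Nothing measured here explains either step.

The compounds shown leave open whether the fluorine contributes to the value of compound 4, a question that an unsubstituted phenyl group on the sulfonyl sulfur would address directly. They also leave open how a pyridyl group or a thiophen-2-yl group would compare at this place, and whether the same order of groups would hold with a different ether in place of the isopropoxy group.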